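Working notes: the step from compound 3 to compound 4

A few compounds are considered here, and "the series" means these few. Any claim that something is new, unique, unknown or untested is made for them only; others in the source may bear on it.

Among the compounds with values here, compound 3 `Cc1nc(-c2ccc(C(F)(F)F)cc2)sc1COc1ccc(OCC(=O)O)c(F)c1` is the one member of the series with a numbered result: in an assay on CHO cells for agonist activity at Free fatty acid receptor 1 (Homo sapiens), read by FLIPR (on this read-out lower numbers stand for an effect already at smaller amounts and higher numbers for an effect only at larger amounts of compound), compound 3 gives 149 nM. Compound 1 `Cc1cc(OCc2sc(-c3ccccc3)nc2C)ccc1OCC(=O)O` reaches only a limit of this assay, > 10000 nM. Compound 2 `Cc1cc(OCc2sc(-c3ccc(C(F)(F)F)cc3)nc2C)ccc1OCC(=O)O` likewise stops at a limit, > 10000 nM. Two of the three values thus sit at the limit of > 10000 nM in this assay, at which 2 of the 3 values shown sit, and compound 3 stands alone as the measured number.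

Compound 4 `Cc1nc(-c2cccc(F)c2)sc1COc1ccc(OCC(=O)O)c(F)c1` differs from compound 3 in one place: 3-fluorophenyl in place of 4-(trifluoromethyl)phenyl on an aromatic carbon. Of the measured steps, an at least 67-fold lower number from compound 2 to compound 3 (1.82 log units; beyond the scatter) concerns the other end of the molecule and does not touch the aromatic group on the five-membered ring. The step that does touch that group, a step that the two limits leave unreadable from compound 1 to compound 2, cannot be read, as both its values are limits. Within the data shown here, no measured step therefore fixes the size of the step into compound 4; the data only show that removing the trifluoromethyl has not been followed by a numbered value.

Compound 4 is expected to give 700 nM, within 150 nM to 4000 nM. The estimated step of a 4.7-fold higher number from compound 3 to compound 4 (0.67 log units; beyond the scatter) leans toward a higher number, with wide uncertainty and a real chance that only a limit is reported.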

Compound 4, half-maximal effective concentration: 185 nM
Beside the measured number, compound 4's estimate is 3.8-fold (0.58 log units) above it, within the range that was stated.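

In this assay, within the data shown here, the swap at this aromatic carbon of the five-membered aromatic ring gives the first readable step at this position: a 1.2-fold higher number from compound 3 to compound 4 (0.09 log units; within the scatter). With the fluoro shared by compound 3 and compound 4 in place, a numbered value therefore does not depend on 4-(trifluoromethyl)phenyl, and 3-fluorophenyl, with fewer heavy atoms, serves equally well within the scatter. The earlier step at this position, from compound 1 to compound 2, cannot be read, as both of its values are limits of the assay: the limit of > 10000 nM in this assay, at which 2 of the 4 values shown sit.

What the compounds shown leave open is how much wider the choice of group at this carbon can be, for example a pyridyl ring, a morpholine or a benzyl group in place of the substituted phenyl. Also open, from the compounds shown here alone, is whether the two phenyl groups would stay within the scatter of each other with a chloro or a methoxy group in place of the fluoro that compound 3 and compound 4 share.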